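The source may hold more compounds than are shown below. What is called first, only, known or untested is meant among the compounds shown, and "the series" means these compounds.

Measured in an assay on isolated protein for inhibition of polyamine deacetylase HDAC10 (Homo sapiens); on this read-out higher numbers stand for weaker inhibition and lower numbers for stronger inhibition:
compound 1, `COc1ccc(C(=O)c2ccc3c(ccn3S(=O)(=O)c3cccc(/C=C/C(=O)NO)c3)c2)cc1`: 5890 nM
compound 2, `COc1ccc(C(=O)c2ccc3c(ccn3S(=O)(=O)c3cccc(/C=C/C(=O)NO)c3)c2)cc1OC`: 8240 nM
compound 3, `O=C(/C=C/c1cccc(S(=O)(=O)n2ccc3cc(C(=O)c4ccc(F)cc4)ccc32)c1)NO`: 5240 nM

Compound 3 sits with compound 1 and compound 2 in one narrow band: the steps of a 1.1-fold lower number from compound 1 to compound 3 (0.05 log units; within the scatter) and a 1.6-fold lower number from compound 2 to compound 3 (0.20 log units; within the scatter) are both within the scatter, as is a 1.4-fold higher number from compound 1 to compound 2 (0.15 log units; within the scatter). Compound 4, `Cc1ccc(C(=O)c2ccc3c(ccn3S(=O)(=O)c3cccc(/C=C/C(=O)NO)c3)c2)cc1`, differs from compound 3 by methyl in place of fluoro on an aromatic carbon. Within the data shown here, the steps that bear on this are the three already named, all changes on the same ring, and none moved the number in this assay beyond the scatter; no step beyond the scatter is therefore expected here either. For compound 4 the estimated value in this assay is 5500 nM, with a range of 2700 nM to 11000 nM. The step this estimate implies, a 1.0-fold higher number from compound 3 to compound 4 (0.02 log units; within the scatter), is expected to stay within the scatter.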

Compound 4, half-maximal inhibitory concentration: 9100 nM
Beside the measured number, compound 4's estimate is 1.7-fold (0.22 log units) below it; the range from low to high includes it.
By their numbers in this assay, from the lowest: compounds 3, 1, 2 and 4 (each within the scatter of the next).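

In this assay, among these compounds, methyl on this aromatic carbon, para to a large group, leaves compound 4 in the same narrow band as the earlier compounds: a 1.7-fold higher number from compound 3 to compound 4 (0.24 log units; within the scatter) and a 1.5-fold higher number from compound 1 to compound 4 (0.19 log units; within the scatter) and a 1.1-fold higher number from compound 2 to compound 4 (0.04 log units; within the scatter) all stay within the scatter. This position has now taken fluoro, methoxy and methyl, and the shift to 3,4-dimethoxyphenyl, without any step beyond the scatter. No evidence on hand accounts for this flat result. On these data alone, whether an amine or a carboxylic acid on this carbon would move the number beyond the scatter remains open.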